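A Sulfonyl Aryl Swap on the Methoxy Analogue

This account rests on a few compounds, and the source may have more. Where it says the series, first, only, none or still open, it means among the compounds named here.

Compound 1 `CC1CCN(c2c(S(=O)(=O)c3cccc(Cl)c3)cnc3ccc(Cl)cc23)CC1`: 92%
Compound 2 `COc1ccc2ncc(S(=O)(=O)c3cccc(Cl)c3)c(N3CCC(C)CC3)c2c1`: -3%
Compound 3 `CC1CCN(c2c(S(=O)(=O)c3cccc(Cl)c3)cnc3ccc(F)cc23)CC1`: 92%

In an assay on isolated protein for displacement of a labelled ligand from metabotropic glutamate receptor 5 (Homo sapiens), with a stated time of 60 min, tested at 1 uM (on this read-out higher numbers stand for more inhibition at the one concentration tested (going by the name of the read-out) and lower numbers for less inhibition), compound 2 stands lowest of the three: a number 95 percentage points lower from compound 1 to compound 2 (beyond the scatter) and a number 95 percentage points higher from compound 2 to compound 3 (beyond the scatter), whereas no change at the digits printed from compound 1 to compound 3 (within the scatter). Compound 4 `COc1ccc2ncc(S(=O)(=O)c3cc(C)cc(C)c3)c(N3CCC(C)CC3)c2c1` keeps the methoxy of compound 2 and alters only the group on the sulfonyl sulfur: 3,5-dimethylphenyl in place of 3-chlorophenyl on a sulfonyl sulfur. Among the measured compounds shown here, no measured step touches that position; the steps in hand all concern the aromatic carbon carrying chloro, fluoro or methoxy. Because compound 2 gives -3% and nothing shows a sulfonyl aryl change restoring displacement, the expected step is a number 8 percentage points higher from compound 2 to compound 4 (within the scatter), within the scatter. Compound 4 is therefore expected at 5%, with a range from -15% to 35%.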

Compound 4, a percentage reported as inhibition, at one concentration (the size of the read-out at that concentration, not a potency): 79%
Compound 4: the middle estimate sits 74 percentage points below what was measured; measured number outside the range, above it.
By their numbers in this assay, from the lowest: compound 2; then compound 4; then compounds 1 and 3 (each within the scatter of the next).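

With the methoxy held fixed, the group on the sulfonyl sulfur proves decisive in this assay: 3,5-dimethylphenyl in place of 3-chlorophenyl gives a number 82 percentage points higher from compound 2 to compound 4 (beyond the scatter). Among the compounds shown here, compound 4 reaches 79% while keeping that methoxy, so the methoxy alone does not settle the read-out, and the sulfonyl aryl group, untouched by the earlier steps, can change it greatly. Nothing available accounts for this step.

On these data alone, whether 3,5-dimethylphenyl acts the same way alongside the chloro of compound 1 or the fluoro of compound 3 remains open. So does what a nitrile or an amine on the aryl group at the sulfonyl sulfur would give.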